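The compounds below may be only part of what the source reports. "The series", "measured", "known", "first", "only" and "open" are said of these compounds alone.

Working notes on the series. The shared core is that of compound 1 `CCOc1ccccc1OC(C)C1=NCCN1`, and the compounds are compared in a functional assay on CHO cells for agonist activity at Alpha-2B adrenergic receptor (Homo sapiens); on this read-out lower numbers stand for an effect already at smaller amounts and higher numbers for an effect only at larger amounts of compound. Compound 1 gives 3160 nM. Among the measured compounds shown here, compound 2 `CC(C)Oc1ccccc1OC(C)C1=NCCN1` gives 1740 nM in this assay and so holds the lower of the two numbers measured so far, though its only neighbour is compound 1 and the step of a 1.8-fold lower number from compound 1 to compound 2 (0.26 log units; within the scatter) stays within the scatter, so the two are not separable.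

Compound 3 `COc1ccccc1OC(C)C1=NCCN1` is not yet measured. It differs from compound 2 by methyl in place of isopropyl on an oxygen on an aromatic ring, the alkyl on that oxygen shrinking rather than growing. For the measured compounds named here, the only measured step bearing on this position is a 1.8-fold lower number from compound 1 to compound 2 (0.26 log units; within the scatter), a change at the same oxygen in the opposite direction and itself within the scatter. A slightly higher number is therefore expected for compound 3, a step of a 2.0-fold higher number from compound 2 to compound 3 (0.30 log units; within the scatter) that may still fall inside the scatter. Compound 3 is estimated at 3500 nM in this assay, with a range from 1400 nM to 9000 nM.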

Compound 3, half-maximal effective concentration: 100000 nM
The estimate for compound 3 lay 29-fold (1.46 log units) below the measured number, outside the stated range (above it).
By their numbers in this assay, from the lowest: compounds 2 and 1 (each within the scatter of the next); then compound 3.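

The alkyl group on this oxygen matters far more than the step between compound 1 and compound 2 suggested: in this assay, isopropoxy to methoxy gives a 57-fold higher number from compound 2 to compound 3 (1.76 log units; beyond the scatter), and hydrogen in place of methyl on the saturated chain carbon bound to that oxygen gives a 32-fold higher number from compound 1 to compound 3 (1.50 log units; beyond the scatter). Both steps are large and of similar size, whereas compound 1 and compound 2 stay within the scatter of each other, so among these three compounds the read-out is not graded with the size of the alkyl group but changes sharply at methyl. Nothing available accounts for this jump.

The compounds shown leave open how a longer chain or a cyclopropylmethyl group on this oxygen would read in this assay. They also leave open whether a hydroxyl in place of the alkoxy group would stay at the high end seen for compound 3.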